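The compounds below may be only part of what the source reports. "The series", "measured", "known", "first", "only" and "open" are said of these compounds alone.

Measured compounds in an ADME assay on the whole organism (Macaca fascicularis) for pharmacokinetics, at a dose of 1 mg/kg by the oral route; on this read-out lower numbers stand for lower exposure and higher numbers for higher exposure at the dose given:
compound 1, `Cc1sc(N(CC2CC2)[C@H](C)c2ccc(-c3cc(Cl)ccc3-c3nc(=O)o[nH]3)cc2)nc1C(=O)O`, gives 2210 ng.h/mL;
compound 2, `Cc1ccc(-c2nc(=O)s[nH]2)c(-c2ccc([C@@H](C)N(CC3CC3)c3nc(C(=O)NS(=O)(=O)C4CC4)c(C4CC4)s3)cc2)c1`, gives 39800 ng.h/mL;
compound 3, `CONC(=O)c1ccc(C)cc1-c1ccc([C@@H](C)N(CC2CC2)c2nc(C(=O)NS(=O)(=O)C3CC3)c(C3CC3)s2)cc1`, gives 24000 ng.h/mL.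

Compound 3 stands second highest of the three numbers in this assay. Its nearest neighbour is compound 2, and the step from compound 2 to compound 3 is a 1.7-fold lower number from compound 2 to compound 3 (0.22 log units; within the scatter), so the two cannot be told apart on this read-out. Compound 1 lies furthest away; compound 1 gives 2210 ng.h/mL against compound 3 at 24000 ng.h/mL, a gap beyond the scatter, and compound 1 also differs from compound 3 in several places at once, so no single change can be read from that pair.

Compound 4, `CNC(=O)c1ccc(C)cc1-c1ccc([C@@H](C)N(CC2CC2)c2nc(C(=O)NS(=O)(=O)C3CC3)c(C3CC3)s2)cc1`, is compound 3 with methyl in place of methoxy on an amide-type nitrogen. Within the data shown here, no measured step touches that amide-type nitrogen: the one measured step, from compound 2 to compound 3, exchanges a group on an aromatic carbon and is itself within the scatter. The data give no reason to expect a step beyond the scatter in this assay for compound 4, so its number is estimated close to that of compound 3. Compound 4 is expected to give 20000 ng.h/mL, between 8000 ng.h/mL and 50000 ng.h/mL, which means an expected step of a 1.2-fold lower number from compound 3 to compound 4 (0.08 log units; within the scatter).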

Compound 4, area under the concentration-time curve: 21400 ng.h/mL
For compound 4 the middle estimate is 1.1-fold (0.03 log units) below the measured one; measured number inside the range.
By their numbers in this assay, from the lowest: compound 1; then compounds 4, 3 and 2 (each within the scatter of the next).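

On the amide-type nitrogen, replacing methoxy with methyl gives a 1.1-fold lower number from compound 3 to compound 4 (0.05 log units; within the scatter) in this assay, so this first reading at that position shows no change that can be told from the scatter, and the exposure at the dose given does not depend on keeping methoxy there rather than methyl. On the aromatic carbon, the methylcarbamoyl group without a ring, in place of the five-membered aromatic ring with 3 hetero atoms, gives a 1.9-fold lower number from compound 2 to compound 4 (0.27 log units; within the scatter), so this replacement also stays within the scatter, as the methoxycarbamoyl group of compound 3 already did. No measured information accounts for either result.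

The compounds shown leave open whether the number in this assay would hold with a plain hydrogen, an ethyl group or a longer chain on the amide-type nitrogen, since methoxy and methyl are the only two groups seen there. They also leave open what a carboxylic acid or a nitrile on the same aromatic carbon would give in place of the carbamoyl groups and the ring.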